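Thiophene for Ethynyl on a Shared Nucleoside Core

This account rests on a few compounds, and the source may have more. Where it says the series, first, only, none or still open, it means among the compounds named here.

Compound 1 `Nc1nc(N)c2c(-c3cc4ccccc4o3)cn([C@@H]3O[C@H](CO)[C@@H](O)[C@H]3O)c2n1`: in a functional assay on CCRF-CEM cells (Homo sapiens), read by MTT assay, with a stated time of 72 h (a higher number here means a weaker inhibitor, a lower number a stronger inhibitor), compound 1 gives > 20000 nM, a limit of the assay.
Compound 2 `C#Cc1cn([C@@H]2O[C@H](CO)[C@@H](O)[C@H]2O)c2ncnc(OC)c12`: in this assay compound 2 gives > 20000 nM, again a limit.
Compound 3 `Nc1nc2c(c(-c3ccccc3)cn2[C@@H]2O[C@H](CO)[C@@H](O)[C@H]2O)c(=O)[nH]1`: in this assay compound 3 gives > 100000 nM, also a limit.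

Compound 2 therefore stands nowhere in particular on a scale of numbers: its result is a limit, not a measured value, and the two other results shown are limits as well, one sitting at the limit of > 100000 nM in this assay, at which 1 of the 3 values shown sits, and two at the limit of > 20000 nM in this assay, at which 2 of the 3 values shown sit. For the measured compounds named here, no pair of measured compounds differs in a single place, so no measured step exists from which a change could be read.

Compound 4 `COc1ncnc2c1c(-c1cccs1)cn2[C@@H]1O[C@H](CO)[C@@H](O)[C@H]1O` is the next compound. Compared with compound 2 the difference is thiophen-2-yl in place of ethynyl on an aromatic carbon. With every measured compound at a limit, the expectation for compound 4 rests on that alone: the step that the limit leaves unreadable from compound 2 to compound 4 is expected to be none beyond the scatter, most likely another limit. Compound 4 is estimated at 30000 nM, within a range from 8000 nM to 100000 nM.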

Compound 4, half-maximal inhibitory concentration: 90 nM
For compound 4 the middle estimate is 330-fold (2.52 log units) above the measured one, outside the stated range (below it).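

For the compounds shown here, at this position, an aromatic carbon of a five-membered aromatic ring with 1 nitrogen, replacing ethynyl with thiophen-2-yl gives the first step that can be read in this assay, with an at least 220-fold lower number from compound 2 to compound 4 (2.34 log units; beyond the scatter) as the result. The two compounds differ in this one place alone, so what sits on this carbon can separate a compound at a limit of the assay from one with a measured value, and the result for compound 2 being a limit means the true step could be larger. Nothing shown here explains why this change has so large an effect.

From the compounds shown here alone, it remains open whether the result depends on the thiophene ring as a whole or on its sulfur. Going by these compounds alone, a pyridine ring, a furan-2-yl group or a plain amine on the same carbon would help to separate these possibilities, and the step itself comes from only one pair of compounds.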